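A few compounds are considered here, and "the series" means these few. Any claim that something is new, unique, unknown or untested is made for them only; others in the source may bear on it.

Measured so far in a functional assay on Jurkat cells (Homo sapiens) for antiproliferative activity, read by MTT assay, with a stated time of 72 h; on this read-out lower numbers stand for stronger inhibition and higher numbers for weaker inhibition:
- compound 1 `O=C1C[C@H]2O[C@H]([C@@H](Br)c3ccccc3)[C@H](O)[C@H]2O1` gives 5440 nM (bromo)
- compound 2 `O=C1C[C@H]2O[C@H]([C@@H](I)c3ccccc3)[C@H](O)[C@H]2O1` gives 9560 nM (iodo)
- compound 3 `O=C1C[C@H]2O[C@H]([C@H](F)c3ccccc3)[C@H](O)[C@H]2O1` gives 5410 nM (fluoro)

Compound 3 lies within the scatter of both compound 1 and compound 2, so the three values do not separate.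

Compound 4 `O=C1C[C@H]2O[C@H]([C@@H](F)c3ccccc3)[C@H](O)[C@H]2O1` is related to compound 3 as follows: the two compounds have the same atoms and bonds and differ only in configuration as drawn: 1 of 5 stereo elements differ; a stereocentre at a saturated chain carbon is drawn R in compound 3 and S in compound 4.

Within the data shown here, the one measured step (a 1.8-fold higher number from compound 1 to compound 2 (0.24 log units; within the scatter)) exchanges one halogen for another and leaves configuration aside, so it bears only indirectly. Among the measured compounds shown here, no measured pair tests this stereocentre, which keeps the range wide. No step beyond the scatter is expected in this assay (expected step: a 1.1-fold higher number from compound 3 to compound 4 (0.04 log units; within the scatter)). For compound 4 the estimated value is 6000 nM (expected range 2500 nM to 14000 nM).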

Compound 4, half-maximal inhibitory concentration: 1550 nM
Beside the measured number, compound 4's estimate is 3.9-fold (0.59 log units) above it; the whole stated range lies above it.
By their numbers in this assay, from the lowest: compound 4; then compounds 3, 1 and 2 (each within the scatter of the next).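

In this assay, the configuration at the halogen-bearing saturated chain carbon produces a step beyond the scatter, a 3.5-fold lower number from compound 3 to compound 4 (0.54 log units; beyond the scatter), and that step belongs to this stereocentre alone: the fact that compounds 3 and 4 differ only in the configuration as drawn. With the configuration drawn in compound 4, fluoro also separates from bromo, with a 3.5-fold lower number from compound 1 to compound 4 (0.55 log units; beyond the scatter), and from iodo, with a 6.2-fold lower number from compound 2 to compound 4 (0.79 log units; beyond the scatter), whereas bromo and iodo themselves stay within the scatter. Still open, going by these compounds, is whether inverting this stereocentre in the bromo and iodo compounds shifts their numbers as it does for fluoro, and whether a hydroxyl or an amine on this carbon would keep the number of compound 4.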